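This account rests on a few compounds, and the source may have more. Where it says the series, first, only, none or still open, it means among the compounds named here.

Compound 1 `Cc1ccc(OCC(=O)N(Cc2cccs2)c2ccccc2)cc1` is the most potent of the three measured compounds in an assay on HEK293 cells for agonist activity at transient receptor potential cation channel subfamily M member 8 (Homo sapiens), read by fluorescence and calcium flux, with a stated time of 15 min (a lower number here means that less compound is needed, a higher number that more compound is needed for the effect), giving 23 nM. Replacing its phenyl on the amide-type nitrogen with 2-methoxyethyl gives compound 2 `COCCN(Cc1cccs1)C(=O)COc1ccc(C)cc1`, which in this assay gives 400 nM, a change of a 17-fold higher number from compound 1 to compound 2 (1.24 log units; beyond the scatter). Compound 3 `Cc1ccc(OCC(=O)N(Cc2cccs2)c2cnn(C)c2)cc1` carries 1-methyl-1H-pyrazol-4-yl in the same place and in this assay gives 63000 nM, the highest number of the three; the step is a 2700-fold higher number from compound 1 to compound 3 (3.44 log units; beyond the scatter), and against compound 2 it is a 160-fold higher number from compound 2 to compound 3 (2.20 log units; beyond the scatter). Compound 4 `Cc1ccc(OCC(=O)N(Cc2cccs2)c2c[nH]nc2C)cc1` differs from compound 3 only in the arrangement of the same atoms: 3-methyl-1H-pyrazol-4-yl in place of 1-methyl-1H-pyrazol-4-yl on an amide-type nitrogen. Going by the values given here, none of the measured steps covers such a rearrangement within the ring; all three replace one group with a different one, so they give no direct guide. The step from compound 3 to compound 4 is therefore expected to be small, a 1.6-fold lower number from compound 3 to compound 4 (0.20 log units; within the scatter), with no clear direction. Compound 4 is estimated to give 40000 nM in this assay, within a range of 10000 nM to 160000 nM.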

Compound 4, half-maximal effective concentration: 0.4 nM
Compound 4: the middle estimate sits 100000-fold (5.00 log units) above what was measured, outside the stated range (below it).
By their numbers in this assay, from the lowest: compound 4; then compound 1; then compound 2; then compound 3.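

In this assay, the group on the amide-type nitrogen matters in its exact arrangement and not only in its make-up: with the same atoms, 3-methyl-1H-pyrazol-4-yl in place of 1-methyl-1H-pyrazol-4-yl gives a 160000-fold lower number from compound 3 to compound 4 (5.20 log units; beyond the scatter) in a single step. The new group also beats both other groups tried here, with a 1000-fold lower number from compound 2 to compound 4 (3.00 log units; beyond the scatter) and a 58-fold lower number from compound 1 to compound 4 (1.76 log units; beyond the scatter) as well, so a pyrazole at this place is not poor in itself, and phenyl is no longer the best group seen. Nothing measured here accounts for a jump of this size.

From the compounds shown here alone, whether the gain goes with the hydrogen-bond donor that enters or with the new place of the methyl stays open. A plain 1H-pyrazol-4-yl or a 1,3-dimethyl-1H-pyrazol-4-yl on the same nitrogen would help to separate the two.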